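This account rests on a few compounds, and the source may have more. Where it says the series, first, only, none or still open, it means among the compounds named here.

Working notes on the series in an ADME assay on Vero cells (Chlorocebus sabaeus) for cytotoxicity, with a stated time of 72 h, tested at 50 ug/mL; a lower number here means a weaker effect, a higher number a stronger effect of the compound at the concentration tested. Compound 1 `Cc1ccc(N2CCn3c2n[nH]c(=O)c3=O)cc1` gives 0% in this assay. Compound 2 `N=c1c(=O)[nH]nc2n1CCN2c1cccc(Cl)c1` gives 0% in this assay, and compound 3 `N/N=C1\NCCN1c1ccccc1` gives 0% in this assay. Compound 1 thus stands level with compound 2 and with compound 3 at the digits reported; the nearest of the two is compound 2, the furthest compound 3, and both lie within the scatter of compound 1. Among the compounds with values here, no step between the measured compounds is set out, and none of the three shows any effect at the concentration tested.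

Compound 4 `COc1ccc(N2CCn3c2n[nH]c(=O)c3=O)cc1` has not yet been measured in this assay. It differs from compound 1 in one place: methoxy in place of methyl on an aromatic carbon. Within the data shown here, none of the measured compounds speaks to this change, and all of them sit at the bottom of the scale in this assay. Compound 4 is expected to show no movement beyond the scatter, a step of no change at the digits printed from compound 1 to compound 4 (within the scatter). The estimate for compound 4 in this assay is 0%, with a range from 0% to 10%.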

Compound 4, a percentage reported as inhibition, at one concentration (the size of the read-out at that concentration, not a potency): 10%
For compound 4 the middle estimate is 10 percentage points below the measured one; measured number inside the range.
By their numbers in this assay, from the lowest: compounds 1, 2, 3 and 4 (each within the scatter of the next).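

In this assay, methoxy in place of methyl on an aromatic carbon, para to a large group, gives a number 10 percentage points higher from compound 1 to compound 4 (within the scatter). Within the data shown here, this is the first reading of a change at this position on the shared core, and it does not separate compound 4 from compound 1 beyond the scatter, so the exchange of methyl for methoxy has no demonstrated effect on the read-out at the concentration tested. No measurement at hand bears on the reason for the reading of compound 4.

Still open, on these data alone, is whether an amine, a carboxylic acid or a longer alkoxy chain at this position would read apart from compound 1. Also open, as far as these compounds go, is whether any change to the core of compound 1 gives a reading clearly beyond the scatter in this assay.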